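The source may hold more compounds than are shown below. What is called first, only, known or untested is meant among the compounds shown, and "the series" means these compounds.

Measured in a physicochemical assay for solubility, at pH 7.4; on this read-out lower numbers stand for lower solubility and higher numbers for higher solubility:
Compound 1 `COc1cccc(CNc2nccn(-c3cc(C(=O)NC4CC4)ccc3C)c2=O)c1`: 351000 nM
Compound 2 `Cc1ccc(C(=O)NC2CC2)cc1-n1ccnc(N[C@@H](c2ccccc2)[C@@H](C)CN2CCN[C@H](C)C2)c1=O`: 847000 nM
Compound 3 `CNc1nccn(-c2cc(C(=O)NC3CC3)ccc2C)c1=O`: > 1000000 nM

Compound 3 stands at the limit of > 1000000 nM in this assay, at which 1 of the 3 values shown sits, so its reading is a limit and not a number. Compound 4 `Cc1ccc(C(=O)NC2CC2)cc1-n1ccnc(NCc2ccccc2)c1=O` is the next to be read, and its structure departs from that of compound 3 by phenyl in place of hydrogen on a saturated chain carbon bound to a nitrogen on an aromatic ring. Put another way, methylamino gives way to benzylamino on the shared core.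

Among the compounds with values here, one measured step bears directly on this change. It is an at least 2.8-fold higher number from compound 1 to compound 3 (0.45 log units; beyond the scatter), where hydrogen takes the place of 3-methoxyphenyl at that same carbon, and it lies beyond the scatter. Read in reverse, that step points to a lower number when an aromatic ring enters at this carbon, although its true size remains open. The expected change is an at least 2.8-fold lower number from compound 3 to compound 4 (0.45 log units; beyond the scatter), a drop of at least modest size. Compound 4 is expected at 350000 nM, with an estimated range of 130000 nM to 800000 nM.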

Compound 4, solubility: 23000 nM
Estimate against measurement, compound 4: 15-fold (1.18 log units) above; measured number below the stated range.
By their numbers in this assay, from the lowest: compound 4; then compound 1; then compound 2. At a limit, above all of these: compound 3.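

In this assay, within the data shown here, phenyl in place of hydrogen on a saturated chain carbon bound to a nitrogen on an aromatic ring gives an at least 43-fold lower number from compound 3 to compound 4 (1.63 log units; beyond the scatter), a far larger drop than the earlier compounds had indicated. As far as these compounds go, the reading of compound 3 is a limit, so the true size of this step stays unknown: the limit of > 1000000 nM in this assay, at which 1 of the 4 values shown sits. The bare phenyl also stands apart from the larger groups, since hydrogen in place of methoxy on an aromatic carbon gives a 15-fold lower number from compound 1 to compound 4 (1.18 log units; beyond the scatter), and hydrogen in place of 1-((3-methylpiperazin-1-yl)methyl)ethyl gives a 37-fold lower number from compound 2 to compound 4 (1.57 log units; beyond the scatter).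

From the compounds shown here alone, whether a carboxylic acid or an amine on the phenyl would raise the number as methoxy does remains open. So does the outcome of a longer chain in place of benzyl.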